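A few compounds are considered here, and "the series" means these few. Any claim that something is new, unique, unknown or untested is made for them only; others in the source may bear on it.

In a functional assay on FaDu cells (Homo sapiens) for cytotoxicity, read by MTT assay, with a stated time of 72 h (on this read-out lower numbers stand for higher toxicity in this test and higher numbers for lower toxicity in this test), compound 1 `COCCn1cc(C(=O)C(=O)Nc2ccc(OCC(=O)O)nc2)c2ccccc21` gives > 10000 nM as a limit of the assay and not a number. Compound 2 `CC(C)Oc1ccc(NC(=O)C(=O)c2cn(C(C)C)c3ccccc23)cn1` gives 408 nM as a measured number and is the only anchor for the expectation that follows. Compound 3 `COCCn1cc(C(=O)C(=O)Nc2ccc(OC(C)(C)C)nc2)c2ccccc21` differs from compound 1 by tert-butyl in place of carboxymethyl on an oxygen on an aromatic ring with tert-butyl in place of carboxymethyl on an oxygen on an aromatic ring. In this assay a large expected step of an at least 16-fold lower number from compound 1 to compound 3 (1.22 log units; beyond the scatter) runs toward lower numbers and lies well beyond the scatter. For compound 3 an estimated 600 nM is expected with 120 nM and 3000 nM as the ends of the range.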

Compound 3, concentration lethal to 50% of the cells: 858 nM
Compound 3: middle estimate off by 1.4-fold (0.16 log units), on the low side, and the stated range covers the measured number.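

In this assay, tert-butyl in place of carboxymethyl on an oxygen on an aromatic ring gives an at least 11-fold lower number from compound 1 to compound 3 (1.06 log units; beyond the scatter), so this position clearly bears on the read-out. The heavy-atom count stays the same, while the one hydrogen-bond donor and one acceptor counted on carboxymethyl leave. The true size of the step stays unfixed, as compound 1 stands only as a limit of the assay: the limit of > 10000 nM in this assay, at which 1 of the 3 values shown sits.

Which part of carboxymethyl matters remains open, since the change replaces the whole group at once. Also open, going by these compounds, is how an amine or a longer chain on the same oxygen would compare with compound 3.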